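Swapping the aryl group on a sulfonamide nitrogen

The compounds below may be only part of what the source reports. "The series", "measured", "known", "first", "only" and "open" are said of these compounds alone.

Measured compounds:
compound 1, `CCc1ccccc1NS(=O)(=O)c1ccc(N2CCNC2=O)cc1`: 240 nM
compound 2, `COc1ccc(NS(=O)(=O)c2ccc(N3CCNC3=O)cc2)cc1`: 800 nM

Of the compounds shown here, two sharing one core have been tested in a functional assay on HT-29 cells (Homo sapiens) for antiproliferative activity, read by sulforhodamine B assay, with a stated time of 48 h; a lower number here means a stronger inhibitor, a higher number a weaker inhibitor. Compound 1 gives 240 nM, the lowest of the two numbers; compound 2 gives 800 nM. Among the measured compounds shown here, the single known step between them is a 3.3-fold higher number from compound 1 to compound 2 (0.52 log units; beyond the scatter), so exchanging the 2-ethylphenyl for another aromatic ring on the sulfonamide nitrogen has, in this one case, made the compound weaker by a modest amount.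

Compound 3, `O=C1NCCN1c1ccc(S(=O)(=O)Nc2ccc(Br)cc2)cc1`, has not yet been tested in this assay. It differs from compound 1 in one place: 4-bromophenyl in place of 2-ethylphenyl on a sulfonamide nitrogen. The change is of the same kind as the step from compound 1 to compound 2, a different six-membered aromatic ring taking the place of 2-ethylphenyl on the sulfonamide nitrogen. For the measured compounds named here, only that one step bears on the question, and it points to a modest weakening; a step of similar direction, a 1.9-fold higher number from compound 1 to compound 3 (0.27 log units; within the scatter), is therefore expected. For compound 3 the expected value in this assay is 450 nM, with a range from 180 nM to 1200 nM.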

Compound 3, half-maximal inhibitory concentration: 300 nM
Compound 3: the middle estimate sits 1.5-fold (0.18 log units) above what was measured; measured number inside the range.
By their numbers in this assay, from the lowest: compounds 1 and 3 (each within the scatter of the next); then compound 2.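

Compound 1's 2-ethylphenyl on the sulfonamide nitrogen can be replaced by another aromatic ring without a measurable loss in this assay: the step to 4-bromophenyl is a 1.3-fold higher number from compound 1 to compound 3 (0.10 log units; within the scatter), so the two groups cannot be told apart here, and the weakening seen with 4-methoxyphenyl does not apply to every replacement. The outcome also depends on what the new ring carries, since bromo in place of methoxy on an aromatic carbon gives a 2.7-fold lower number from compound 2 to compound 3 (0.43 log units; beyond the scatter), a modest step that is larger than the usual scatter of repeat measurements. Nothing available explains why these groups differ in this way.

With only three aromatic groups shown, a trend cannot yet be drawn, and it remains open how an amine or a carboxylic acid on the aromatic ring would compare with bromo and methoxy. As far as these compounds go, it is also open whether the ring needs to be aromatic at all, which a cyclohexyl group on the sulfonamide nitrogen would test.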